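The compounds below may be only part of what the source reports. "The series", "measured", "known", "first", "only" and "open" are said of these compounds alone.

Series notes. Compound 1 `COc1c(OC)c(OC(C)=O)c2ccccc2c1OC(C)=O` is the simplest member; in a physicochemical assay for lipophilicity (a higher number here means a more lipophilic compound, a lower number a more polar compound), compound 1 gives 2.39. Compound 3 `COc1c(OC)c(OC(C)=O)c2c(Cl)cccc2c1OC(C)=O` differs from compound 1 by chloro in place of hydrogen on an aromatic carbon. In this assay compound 3 gives 3.16, so that the step of a number 0.77 log units higher from compound 1 to compound 3 (beyond the scatter). Compound 2 `CC(C)(C)C(=O)Oc1c(Oc2ccccc2)c(Oc2ccccc2)c(OC(=O)C(C)(C)C)c2ccccc12` belongs to the same series but the difference between its core and the core of compound 1 is not broken down here. In this assay compound 2 gives 7.8, the highest of the three numbers. Compound 4 `CC(C)(C)C(=O)Oc1c(Oc2ccccc2)c(Oc2ccccc2)c(OC(=O)C(C)(C)C)c2cc(Cl)ccc12`, not yet measured, differs from compound 2 by chloro in place of hydrogen on an aromatic carbon. Among the measured compounds shown here, this is the same kind of change as the one from compound 1 to compound 3, not the same: in compound 3 the chloro is ortho to a fused ring and meta to a fused ring, whereas in compound 4 it is meta to a fused ring and para to a fused ring. For compound 4 a step of a number 0.70 log units higher from compound 2 to compound 4 (beyond the scatter) is expected in this assay, close to the earlier one, resting on a number 0.77 log units higher from compound 1 to compound 3 (beyond the scatter). Compound 4 is therefore estimated at 8.5 in this assay, most likely between 8 and 9.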

Compound 4, partition coefficient: 8.7
Compound 4: middle estimate off by 0.20 log units, on the low side; the range from low to high includes it.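

The new step in this assay (a number 0.90 log units higher from compound 2 to compound 4 (beyond the scatter)) runs the same way as the earlier one (a number 0.77 log units higher from compound 1 to compound 3 (beyond the scatter)), and both are modest, so in these two pairs chloro in place of hydrogen on an aromatic carbon raises the number on either core. Among the compounds shown here, this does not establish a general rule: there is one pair per core, and in compound 4 the chloro is meta to a fused ring and para to a fused ring, a different place from the one it holds in compound 3, so the change of core and the change of place cannot be separated. No measurement offered here bears on the cause of either step.

The compounds shown leave open whether chloro at one and the same place would give a like step on both cores. They also leave open whether another group, such as an amine or a carboxylic acid, would carry over from one core to the other as chloro does here.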